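Pyrimidine change on the sulfonamide: compound 2 to compound 4

A few compounds are considered here, and "the series" means these few. Any claim that something is new, unique, unknown or untested is made for them only; others in the source may bear on it.

In a functional assay on SF-295 cells (Homo sapiens) for antiproliferative activity, read by sulforhodamine B assay, with a stated time of 72 h (on this read-out lower numbers stand for stronger inhibition and higher numbers for weaker inhibition), compound 1 (`CCN1C(=O)CS/C1=N/Nc1nncc2ccccc12`) gives 3.5 nM while compound 2 (`Cc1cc(C)nc(NS(=O)(=O)c2ccc(Nc3nncc4ccccc34)cc2)n1`) gives 0.56 nM and compound 3 (`C(=C/c1ccccc1)\C(=N\Nc1nncc2ccccc12)c1ccccc1`) gives 0.33 nM on the same read-out. Compound 2 stands second highest of the three numbers, within the scatter of compound 3 and beyond the scatter from the higher number of compound 1. Compound 4 (`O=S(=O)(Nc1ncccn1)c1ccc(Nc2nncc3ccccc23)cc1`) carries pyrimidin-2-yl in place of 4,6-dimethylpyrimidin-2-yl on a sulfonamide nitrogen. Within the data shown here, no measured pair isolates this change, so, starting from compound 2 at 0.56 nM in this assay, no step beyond the scatter is expected in either direction. The estimated step is a 1.1-fold higher number from compound 2 to compound 4 (0.03 log units; within the scatter) and stays within the scatter. Compound 4 is estimated at 0.6 nM (expected range 0.2 nM to 1.8 nM).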

Compound 4, half-maximal inhibitory concentration: 7.6 nM
Beside the measured number, compound 4's estimate is 13-fold (1.10 log units) below it; measured number above the stated range.
By their numbers in this assay, from the lowest: compounds 3 and 2 (each within the scatter of the next); then compound 1; then compound 4.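

In this assay, among these compounds, taking the methyl groups off the pyrimidine gives a 14-fold higher number from compound 2 to compound 4 (1.13 log units; beyond the scatter) as a large step, the first single change that can be read. The group on the sulfonamide nitrogen is therefore not a neutral place on the shared core, and the methyl groups of 4,6-dimethylpyrimidin-2-yl count for much of the low number of compound 2. No available data explain the size of this step.

Open, on these data alone, is whether 4-methylpyrimidin-2-yl alone recovers that number. Also open, as far as these compounds go, is how 4,6-dimethoxypyrimidin-2-yl or 4,6-diethylpyrimidin-2-yl on the same nitrogen would read.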